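This account rests on a few compounds, and the source may have more. Where it says the series, first, only, none or still open, it means among the compounds named here.

Permeability notes on the series. Going by the values given here, compound 3 `COc1cc(C)c(S(=O)(=O)N(C)CCOCC(=O)N2CCN([C@H]3CN4CCC3CC4)CC2)c(C)c1` gives 1.9 10^-6 cm/s in an ADME assay on Caco-2 cells (Homo sapiens) for permeability, tested at 50 uM; on this read-out lower numbers stand for lower permeability and higher numbers for higher permeability; it stands second highest of the three numbers measured so far. Compound 1 `COc1cc(C)c(S(=O)(=O)N(C)CCOCC(=O)N2CCN(C3CCN(C4CC4)CC3)CC2)c(C)c1` gives 11.8 10^-6 cm/s, and the step of a 6.2-fold lower number from compound 1 to compound 3 (0.79 log units; beyond the scatter) is modest. Compound 2 `COc1cc(C)c(S(=O)(=O)N(C)CCOCC(=O)N2CCN(CCCN(C)C)CC2)c(C)c1` gives 0.1 10^-6 cm/s, and the step of a 19-fold higher number from compound 2 to compound 3 (1.28 log units; beyond the scatter) is large; the step of a 120-fold lower number from compound 1 to compound 2 (2.07 log units; beyond the scatter) is the largest in the set.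

Compound 4 `COc1cc(C)c(S(=O)(=O)N(C)CCOCC(=O)N2CCN(CC3CCN(C)CC3)CC2)c(C)c1` is the next member. The change is a group of 8 heavy atoms (7 carbon, 1 nitrogen; one six-membered non-aromatic ring with 1 hetero atom) in place of a group of 8 heavy atoms (7 carbon, 1 nitrogen; 2 six-membered non-aromatic rings with 1 hetero atom each), on an amine nitrogen in a ring: the entering group, (1-methylpiperidin-4-yl)methyl, carries one six-membered non-aromatic ring where the leaving group carries two. Among the compounds with values here, the steps that bear on it are the steps from compound 2 to compound 3 and from compound 1 to compound 3, which show that exchanging the group on this ring nitrogen moves the read-out by large amounts in either direction. The entering group lies, in what is counted, between the open chain of compound 2 and the two-ring group of compound 3, so a decrease beyond the scatter is expected, on the order of a 2.4-fold lower number from compound 3 to compound 4 (0.38 log units; beyond the scatter). Compound 4 is accordingly estimated at 0.8 10^-6 cm/s, within 0.15 10^-6 cm/s to 4 10^-6 cm/s in this assay.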

Compound 4, apparent permeability: 1.5 10^-6 cm/s
The estimate for compound 4 lay 1.9-fold (0.27 log units) below the measured number, within the range that was stated.
By their numbers in this assay, from the lowest: compound 2; then compounds 4 and 3 (each within the scatter of the next); then compound 1.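

In this assay the step of a 1.3-fold lower number from compound 3 to compound 4 (0.10 log units; within the scatter) puts (1-methylpiperidin-4-yl)methyl and the two-ring group on the same level on this amine nitrogen in a ring, although the entering group has one six-membered non-aromatic ring where the leaving group has two. The other two steps are a 15-fold higher number from compound 2 to compound 4 (1.18 log units; beyond the scatter) and a 7.9-fold lower number from compound 1 to compound 4 (0.90 log units; beyond the scatter) and both stay beyond the scatter, so the count of rings alone does not order the series: compound 3 and compound 1 each carry two rings, yet only compound 3 lies within the scatter of compound 4. No measurement on hand accounts for these steps.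

The compounds shown leave open which feature of 1-cyclopropylpiperidin-4-yl goes with the higher number of compound 1. A 1-methylpiperidin-4-yl group on the same nitrogen would separate the cyclopropyl from the methylene link of compound 4.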